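This account rests on a few compounds, and the source may have more. Where it says the series, first, only, none or still open, it means among the compounds named here.

Of the compounds shown here, three have so far been measured in a toxicity assay on HEK-293T cells (Homo sapiens) for cytotoxicity, read by MTT assay, with a stated time of 72 h; on this read-out lower numbers stand for stronger inhibition and higher numbers for weaker inhibition. Compound 1 `CC1(C)O[C@@H](CO)[C@H](Cn2cc(Cn3c4c(c5ccccc53)C(=O)c3c[n+]([O-])c5ccccc5c3C4=O)nn2)O1` gives 120 nM, compound 2 `O=C1c2c[n+]([O-])c3ccccc3c2C(=O)c2[nH]c3ccccc3c21` gives 890 nM, and compound 3 `O=C1c2c[n+]([O-])c3ccccc3c2C(=O)c2c1c1ccccc1n2Cc1cn([C@@H]2O[C@H](CO)[C@@H](O)[C@H](O)[C@H]2O)nn1` gives 940 nM. Compound 2 therefore stands second highest of the three, within the scatter of compound 3 and beyond the scatter of compound 1. Among the compounds with values here, the only measured step, a 7.8-fold higher number from compound 1 to compound 3 (0.89 log units; beyond the scatter), swaps one group for another on the same aromatic nitrogen. Compound 4 `O=C1c2c[n+]([O-])c3ccccc3c2C(=O)c2c1c1ccccc1n2CCCN1CCC(O)CC1` differs from compound 2 by 3-(4-hydroxypiperidin-1-yl)propyl in place of hydrogen on an aromatic nitrogen. Within the data shown here, no measured step adds a group to that nitrogen where only hydrogen stood, but compounds 1 and 3, which both carry a group there, sit at or below compound 2, so a modest step down is expected. Compound 4 is estimated at 400 nM, between 100 nM and 1500 nM, which would be a 2.2-fold lower number from compound 2 to compound 4 (0.35 log units; beyond the scatter).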

Compound 4, half-maximal inhibitory concentration: 170 nM
Beside the measured number, compound 4's estimate is 2.4-fold (0.37 log units) above it; the measured number falls inside the stated range.
By their numbers in this assay, from the lowest: compounds 1 and 4 (each within the scatter of the next); then compounds 2 and 3 (each within the scatter of the next).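

Placing 3-(4-hydroxypiperidin-1-yl)propyl on the aromatic nitrogen in place of hydrogen gives, in this assay, a 5.2-fold lower number from compound 2 to compound 4 (0.72 log units; beyond the scatter). Within the data shown here, this is the first measured step away from hydrogen at this position, and it shows that a group added there can lower the number beyond the scatter. No experimental evidence here explains this change.

As far as these compounds go, it remains open whether the hydroxyl, the piperidine ring or the propyl chain matters most. A 3-(piperidin-1-yl)propyl group, a morpholine ring or a longer butyl chain would help separate these parts.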